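A few compounds are considered here, and "the series" means these few. Any claim that something is new, unique, unknown or untested is made for them only; others in the source may bear on it.

Measured so far in an in vitro ADME assay on microsomes from liver (Homo sapiens) for metabolic stability, tested at 1 uM; a higher number here means faster removal of the compound, a lower number slower removal:
Compound 1, `COC(=O)c1cc(N)c(Nc2ccc(C#N)cc2)cc1Oc1c(C)cc(/C=C/C#N)cc1C`, gives 20 mL.min-1.g-1.
Compound 2, `Cc1cc(CCC#N)cc(C)c1Oc1cc(Nc2ccc(C#N)cc2)c(N)cc1C(N)=O`, gives 160 mL.min-1.g-1.
Compound 3, `Cc1cc(/C=C/C#N)cc(C)c1Oc1cc(Nc2ccc(C#N)cc2)c(N)cc1C(N)=O`, gives 200 mL.min-1.g-1.

Among these three numbers compound 2 stands second highest. Compound 3 sits closest to it, and the difference between the two is within the usual scatter. Compound 1 gives the lowest number of the set, clearly below compound 2.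

Compound 4, `Cc1cc(CCC#N)cc(C)c1Oc1cc(Nc2ccc(C#N)cc2)c(N)cc1CO`, is compound 2 with one change: hydroxymethyl in place of carbamoyl on an aromatic carbon.

Neither measured step covers this exact exchange. The closest is a 10-fold higher number from compound 1 to compound 3 (1.00 log units; beyond the scatter), which touched the same carbonyl group but only swapped amino for methoxy on it; the carbamoyl itself stayed. The other step, a 1.3-fold higher number from compound 2 to compound 3 (0.10 log units; within the scatter), concerns a different part of the molecule and was within the scatter. Among the measured compounds shown here, with no direct precedent, a change in either direction cannot be ruled out, and the expectation is a step of a 1.1-fold lower number from compound 2 to compound 4 (0.06 log units; within the scatter), that is, none beyond the scatter.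

Compound 4 is therefore expected to give about 140 mL.min-1.g-1 in this assay, with a range from 50 mL.min-1.g-1 to 400 mL.min-1.g-1.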

Compound 4, intrinsic clearance in microsomes: 330 mL.min-1.g-1
Compound 4: the middle estimate sits 2.4-fold (0.37 log units) below what was measured; the measured number falls inside the stated range.
By their numbers in this assay, from the lowest: compound 1; then compounds 2, 3 and 4 (each within the scatter of the next, the first and the last beyond it).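

In this assay, exchanging carbamoyl for hydroxymethyl on this aromatic carbon gives a 2.1-fold higher number from compound 2 to compound 4 (0.31 log units; beyond the scatter), so this exchange moves the number beyond the scatter. Among the compounds shown here, earlier, the only change at this position was to the group on the carbonyl carbon, with a 10-fold higher number from compound 1 to compound 3 (1.00 log units; beyond the scatter), and the carbonyl itself stayed in place. Here the whole carbamoyl leaves, and the number goes up rather than down, with the 2-cyanoethyl chain and the rest of the molecule unchanged.

Nothing measured here explains this rise. On these data alone, whether a carboxylic acid or an aminomethyl group on this carbon would give a lower number remains open, as does whether hydroxymethyl in place of carbamoyl gives a similar step in a compound carrying 2-cyanoethenyl in place of 2-cyanoethyl.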